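Swapping nitro for isopropyl on compound 2

The source may hold more compounds than are shown below. What is called first, only, known or untested is meant among the compounds shown, and "the series" means these compounds.

Among the measured compounds shown here, in a functional assay on MCF7 cells (Homo sapiens) for cytotoxicity, read by MTT assay, with a stated time of 48 h (a lower number here means a stronger inhibitor, a higher number a weaker inhibitor), compound 2 `O=C1/C(=C\c2ccc([N+](=O)[O-])cc2)S/C(=N/c2ccccc2)N1Cc1ccncc1` gives 13000 nM and so holds the lower of the two numbers so far, while compound 1 `O=C1/C(=C\c2ccc(Cl)cc2)S/C(=N/c2ccccc2)N1Cc1ccncc1` gives 54900 nM as the higher one. Compound 3 `CC(C)c1ccc(/C=C2/S/C(=N/c3ccccc3)N(Cc3ccncc3)C2=O)cc1` carries isopropyl in place of nitro on an aromatic carbon. Going by a 4.2-fold lower number from compound 1 to compound 2 (0.63 log units; beyond the scatter) for nitro in place of chloro, the only measured step at this place and a modest one, a step of like size to a higher number is expected in this assay when nitro leaves. The expected move is a 3.1-fold higher number from compound 2 to compound 3 (0.49 log units; beyond the scatter) in size. Compound 3 is estimated at 40000 nM (expected range 12000 nM to 110000 nM).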

Compound 3, half-maximal inhibitory concentration: 53300 nM
The estimate for compound 3 lay 1.3-fold (0.12 log units) below the measured number, within the range that was stated.
By their numbers in this assay, from the lowest: compound 2; then compounds 3 and 1 (each within the scatter of the next).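

In this assay the swap of nitro for isopropyl gives a 4.1-fold higher number from compound 2 to compound 3 (0.61 log units; beyond the scatter) and so takes back the earlier gain, which ties the lower number to nitro itself rather than to any move away from chloro. With a 1.0-fold lower number from compound 1 to compound 3 (0.01 log units; within the scatter) as the step between them, chloro and isopropyl stand level, so among these three groups on the aromatic carbon only nitro stands apart. As far as these compounds go, whether an amine, a carboxylic acid or a methoxy group here would match nitro or the other two stays open. No measurement at hand explains why nitro differs.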